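A few compounds are considered here, and "the series" means these few. Any claim that something is new, unique, unknown or untested is made for them only; others in the source may bear on it.

Measured compounds:
compound 1 `CCCCCCCCCCCC(=O)Nc1nnc(S[C@@H]2O[C@H](COC(C)=O)[C@H](OC(C)=O)[C@H](OC(C)=O)[C@H]2OC(C)=O)s1`, 16900 nM;
compound 2 `CCCCCCCC/C=C\CCCCCCCCCCCC(=O)Nc1nnc(S[C@@H]2O[C@H](COC(C)=O)[C@H](OC(C)=O)[C@H](OC(C)=O)[C@H]2OC(C)=O)s1`, 28400 nM;
compound 3 `CCCCCCCC/C=C\CCCCCCCCCCCC(=O)Nc1nnc(S[C@@H]2O[C@H](CO)[C@H](O)[C@H](O)[C@H]2O)s1`, "not active" (no number reported).

In a functional assay on DU-145 cells (Homo sapiens) for cytotoxicity, read by MTT assay, with a stated time of 24 h (on this read-out higher numbers stand for weaker inhibition and lower numbers for stronger inhibition), compound 1 gives 16900 nM and compound 2 gives 28400 nM. The change hydrogen in place of dec-1-en-1-yl on a saturated chain carbon, ten or more bonds along the chain from a carbonyl carbon made a step of a 1.7-fold lower number from compound 2 to compound 1 (0.23 log units; within the scatter). Compound 3, which differs from compound 2 in its core, was reported in this assay as not active; the difference between the two cores is not broken down here. Compound 4 `CCCCCCCCCCCC(=O)Nc1nnc(S[C@@H]2O[C@H](CO)[C@H](O)[C@H](O)[C@H]2O)s1` carries the same kind of change as compound 2 to compound 1, namely (hydrogen in place of dec-1-en-1-yl on a saturated chain carbon, ten or more bonds along the chain from a carbonyl carbon). Since that step was within the scatter, a similar small step from compound 3 to compound 4 in this assay is expected, starting from a compound reported as inactive. Compound 4 is therefore expected to give about 45000 nM, within 15000 nM to 150000 nM, with a real chance that only a limit is reported.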

Compound 4, half-maximal inhibitory concentration: "not active" (no number reported)
Nothing numeric was reported for compound 4, so the estimate cannot be set against anything.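

Among the compounds shown here, compound 3 and compound 4 were both reported as not active in this assay, so no step between them can be read. The compounds shown leave open whether the chain change matters on their core. No evidence on this result is available.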